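Trimming the Sulfonamide Aryl Group: Compound 3 to Compound 4

The compounds below may be only part of what the source reports. "The series", "measured", "known", "first", "only" and "open" are said of these compounds alone.

Compound 1 `COc1cccc(Oc2c(NS(=O)(=O)c3ccc(C(C)(C)C)cc3)ncnc2OCCOc2ncc(C)cn2)c1`: 0.86 nM
Compound 2 `Cc1ccc(-c2c(NS(=O)(=O)c3ccc(C(C)(C)C)cc3)ncnc2OCCOc2ncc(Cl)cn2)cc1`: < 0.001 nM
Compound 3 `CCC(C)(C)c1ccc(S(=O)(=O)Nc2ncnc(OCCOc3ncc(Br)cn3)c2-c2ccc(C)cc2)cc1`: < 0.001 nM

All three were tested in an assay on cells (Endothelial cell) for binding affinity to Endothelin-1 receptor (Sus scrofa); on this read-out higher numbers stand for weaker inhibition and lower numbers for stronger inhibition. The value for compound 3 is a limit of the assay, not a number. Compound 2 also sits at a limit, as noted in the limit of < 0.001 nM in this assay, at which 2 of the 3 values shown sit. Only compound 1 gives a number in this assay, so no size of change between measured compounds can be read off. Compound 4 `Cc1ccc(-c2c(NS(=O)(=O)c3ccc(C(C)C)cc3)ncnc2OCCOc2ncc(Br)cn2)cc1` differs from compound 3 by hydrogen in place of ethyl on a saturated chain carbon bound to an aromatic carbon and two saturated chain carbons. With compound 3 at the limit, a modest weakening would be the most that could become visible, and none beyond the scatter is expected. Compound 4 is therefore expected to stay near the limit, a step of an at least 2.0-fold higher number from compound 3 to compound 4 (0.30 log units; that floor lies within the scatter), giving an estimate of 0.002 nM with a range from 0.0003 nM to 0.02 nM.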

Compound 4, half-maximal inhibitory concentration: 0.16 nM
Compound 4: the middle estimate sits 80-fold (1.90 log units) below what was measured, outside the stated range (above it).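

In this assay, among these compounds, going from 4-(1,1-dimethylpropyl)phenyl to 4-isopropylphenyl gives an at least 160-fold higher number from compound 3 to compound 4 (2.20 log units; beyond the scatter), so this place does not tolerate the change silently: removing an ethyl here has a large effect on the read-out, which the earlier compounds could not show. The printed step is a floor rather than a full size, because the value of compound 3 is a limit of the assay: the limit of < 0.001 nM in this assay, at which 2 of the 4 values shown sit.

From the compounds shown here alone, how a cyclopropyl group or a methyl group would read in place of the isopropyl stays open.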